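The compounds below may be only part of what the source reports. "The series", "measured", "known", "first", "only" and "open" are said of these compounds alone.

Measured compounds:
Compound 1: `CCOc1cc(C(C)(C)C)ccc1C1=NC(c2ccc(Cl)cc2)C(c2ccc(Cl)cc2)N1C(=O)NCCCCC(=O)Nc1ccccc1N`, 18400 nM
Compound 2: `CCOc1cc(C(C)(C)C)ccc1C1=NC(c2ccc(Cl)cc2)C(c2ccc(Cl)cc2)N1C(=O)N1CCN(CCCCCCCC(=O)NO)CC1`, 2010 nM
Compound 3: `CCOc1cc(C(C)(C)C)ccc1C1=NC(c2ccc(Cl)cc2)C(c2ccc(Cl)cc2)N1C(=O)NCCCCCCCC(=O)NO`, 4850 nM

In a functional assay on A549 cells (Homo sapiens) for antiproliferative activity, read by CCK-8 assay, with a stated time of 72 h (a lower number here means a stronger inhibitor, a higher number a weaker inhibitor), compound 3 stands with the second-highest number of the three measured compounds. Its nearest neighbour is compound 2, whose number is lower, and the furthest is compound 1, whose number is higher; both gaps lie beyond the scatter. Compound 4 is `CCOc1cc(C(C)(C)C)ccc1C1=NC(c2ccc(Cl)cc2)C(c2ccc(Cl)cc2)N1C(=O)NCCCCCCC(=O)Nc1ccccc1N`, and it differs from compound 3 in one place: (2-aminophenyl)carbamoyl in place of (hydroxycarbamoyl)methyl on a saturated chain carbon, six bonds along the chain from an amide-type nitrogen. For the measured compounds named here, the one measured step that bears on this change runs the other way, from the (2-aminophenyl)carbamoyl end group of compound 1 to the hydroxycarbamoyl end group of compound 3, and it read a 3.8-fold lower number from compound 1 to compound 3 (0.58 log units; beyond the scatter). Reversing that exchange on a longer chain therefore points toward a higher number for compound 4, and the account expects a step of about a 3.1-fold higher number from compound 3 to compound 4 (0.49 log units; beyond the scatter), though no measured pair shows what the extra chain length on its own would do. Compound 4 is estimated at 15000 nM in this assay, within a range from 5000 nM to 45000 nM.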

Compound 4, half-maximal inhibitory concentration: 16000 nM
Estimate against measurement, compound 4: 1.1-fold (0.03 log units) below, within the range that was stated.
By their numbers in this assay, from the lowest: compound 2; then compound 3; then compounds 4 and 1 (each within the scatter of the next).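

In this assay, the exchange on the longer chain gives a 3.3-fold higher number from compound 3 to compound 4 (0.52 log units; beyond the scatter) and so shows the end group mattering between two compounds of equal chain length, which the earlier step, where chain length changed as well, could not show. Lengthening the chain under the (2-aminophenyl)carbamoyl end group gives a 1.2-fold lower number from compound 1 to compound 4 (0.06 log units; within the scatter) and so leaves this end group's number unmoved between these two chain lengths. Nothing at hand explains either step.

As far as these compounds go, it remains open what the hydroxycarbamoyl end group would give on the shorter chain of compound 1, so the effect of chain length with that end group is unknown. Also open, from the compounds shown here alone, is how a carboxylic acid or a primary amide would read at the end of the chain.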